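Amide variation on the shared core: clearance notes

The compounds below may be only part of what the source reports. "The series", "measured", "known", "first", "only" and "open" are said of these compounds alone.

Measured so far:
compound 1 `O=C(C1CCC(F)(F)CC1)N1CC(c2nc(-c3cccc(Cl)c3)no2)C1`: 24 mL/min
compound 2 `O=C([C@H]1CC2CCC1C2)N1CC(c2nc(-c3cccc(F)c3)no2)C1`: 16 mL/min

In an ADME assay on microsomes from liver (Rattus norvegicus) for metabolic stability (a higher number here means faster removal of the compound, a lower number slower removal), compound 2 gives the lowest of the two numbers; its nearest neighbour is compound 1, whose number is higher but only by an amount within the usual scatter, so no order between the two is claimed.

Compound 3 `CC1CCCCC1C(=O)N1CC(c2nc(-c3cccc(F)c3)no2)C1` is not yet measured in this assay. It differs from compound 2 in one place: a group of 7 heavy atoms (7 carbon; one six-membered non-aromatic ring of carbon only) in place of a group of 7 heavy atoms (7 carbon; 2 five-membered non-aromatic rings of carbon only), on a carbonyl carbon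

Among the compounds with values here, with no step between measured compounds to lean on, the expected step of a 1.3-fold higher number from compound 2 to compound 3 (0.10 log units; within the scatter) is small, within the scatter, and compound 3 is estimated at 20 mL/min (range 10 mL/min to 40 mL/min).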

Compound 3, intrinsic clearance in a liver preparation (reported as CLH), per the amount of preparation that the assay uses in the Rattus norvegicus assay: 13 mL/min
Beside the measured number, compound 3's estimate is 1.5-fold (0.19 log units) above it; the measured number falls inside the stated range.
By their numbers in the Rattus norvegicus assay, from the lowest: compounds 3, 2 and 1 (each within the scatter of the next).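

In the Rattus norvegicus assay, 2-methylcyclohexyl in place of the group with two five-membered carbon rings, on the carbonyl carbon, gives a 1.2-fold lower number from compound 2 to compound 3 (0.09 log units; within the scatter), so this read-out does not separate the pair. Within the data shown here, in a physicochemical assay for solubility, read by HPLC, in phosphate buffer, with a stated time of 4 h (on this read-out lower numbers stand for lower solubility and higher numbers for higher solubility), compound 2 gives 54000000 nM and compound 3 gives 180000000 nM, which is a 3.3-fold higher number from compound 2 to compound 3 (0.52 log units; beyond the scatter), the first step beyond the scatter at this position.

As far as these compounds go, what a longer chain or a group carrying an amine or a carboxylic acid would give at this carbonyl carbon stays open. This single step speaks only for this pair.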